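The compounds below may be only part of what the source reports. "The series", "measured", "known", "first", "only" and "open" are said of these compounds alone.

Compound 1 `Cc1ccn2nc(C)c(C(=O)NCc3ccc(N4CCC(c5ccc(OC(F)(F)F)cc5)CC4)cc3)c2c1` and compound 2 `Cc1nn2ccc(Cl)cc2c1C(=O)NCc1ccc(N2CCC(c3ccc(OC(F)(F)F)cc3)CC2)cc1` share one core and differ at a single aromatic carbon. In an ADME assay on Vero cells (Chlorocebus sabaeus) for cytotoxicity, read by CCK-8 assay, with a stated time of 72 h (a higher number here means a weaker inhibitor, a lower number a stronger inhibitor), compound 1 gives > 100000 nM, which is a limit of the assay and not a number. In this assay compound 2 gives > 100000 nM, again a limit rather than a number. The step that the two limits leave unreadable from compound 1 to compound 2 therefore cannot be read, since (the limit of > 100000 nM in this assay, at which 2 of the 2 values shown sit). For the measured compounds named here, compound 2 thus stands at that limit, as does the only other value shown. Compound 3 `Cc1nn2ccc(C(F)(F)F)cc2c1C(=O)NCc1ccc(N2CCC(c3ccc(OC(F)(F)F)cc3)CC2)cc1` arises from compound 2 by the change (trifluoromethyl in place of chloro on an aromatic carbon), trifluoromethyl in place of chloro on an aromatic carbon, opposite the ring nitrogen. Going by the values given here, the single measured step concerns this same carbon, but its size is unreadable, so no movement beyond the scatter is expected in this assay. The expected step that the limit leaves unreadable from compound 2 to compound 3 is essentially none. Compound 3 is expected to give 150000 nM, within a range from 50000 nM to 500000 nM, most likely again as a limit.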

Compound 3, half-maximal inhibitory concentration: > 100000 nM
Compound 3: only a limit was reported; the forecaster's own chance of this, stated with the estimate: 85%; the middle value is on the limit's open side.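

Neither the step from compound 2 to compound 3 nor the step from compound 1 to compound 3 can be read, as compound 3 also gives only a limit: the limit of > 100000 nM in this assay, at which 3 of the 3 values shown sit.

Going by these compounds, how methyl, chloro and trifluoromethyl on this aromatic carbon compare in this assay remains open.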